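This account rests on a few compounds, and the source may have more. Where it says the series, first, only, none or still open, it means among the compounds named here.

Going by the values given here, in a functional assay on HCT-116 cells (Homo sapiens) for antiproliferative activity, read by sulforhodamine B assay, with a stated time of 72 h (on this read-out lower numbers stand for stronger inhibition and higher numbers for weaker inhibition), compound 1 `Cn1ncc(Cl)c1-c1cc(C(=O)N[C@@H]2CNCC[C@H]2c2ccc(C(F)(F)F)cc2)oc1Cl` gives 280 nM and holds the lowest of the three numbers measured so far. Compound 2 `C=CC[C@@H]1C[C@@H](c2ccc(Cl)c(Cl)c2)[C@H](NC(=O)c2cc(-c3c(Cl)cnn3C)c(Cl)o2)CN1` stands at 780 nM and compound 3 `O=C(N[C@@H]1CNCC[C@H]1c1ccc(Cl)cc1)c1ccc(-c2ncnc3c2CCC3O)s1` at 23000 nM with both gaps to compound 1 lying beyond the scatter. The next compound to be tested is compound 4 `Cn1ncc(Cl)c1-c1cc(C(=O)N[C@H]2CNCC[C@@H]2c2ccc(C(F)(F)F)cc2)oc1Cl` which has the same atoms and bonds as compound 1 and differs only in configuration as drawn (the two compounds have the same atoms and bonds and differ only in configuration as drawn: 2 of 2 stereo elements differ (all stereocentres are inverted: mirror images); a stereocentre at a saturated ring carbon is drawn S in compound 1 and R in compound 4; a stereocentre at a saturated ring carbon is drawn S in compound 1 and R in compound 4) so that the two are mirror images. Among the compounds with values here, no pair of mirror images has been measured here, and the data therefore give no direct size for such a step. A higher number, meaning weaker inhibition, is nevertheless expected in this assay and the step should lie beyond the scatter. This expectation rests only on where the numbers stand: compound 1 at 280 nM sits at the low end of a range that reaches compound 3 at 23000 nM and leaves far more room upward than downward. The estimated change is the step of an 8.9-fold higher number from compound 1 to compound 4 (0.95 log units; beyond the scatter) and its size remains uncertain. For compound 4 the expected value is 2500 nM with an estimated range from 500 nM to 10000 nM in this read-out.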

Compound 4, half-maximal inhibitory concentration: 1050 nM
Estimate against measurement, compound 4: 2.4-fold (0.38 log units) above; low and high end bracket the measured number.
By their numbers in this assay, from the lowest: compound 1; then compounds 2 and 4 (each within the scatter of the next); then compound 3.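

In this assay, inverting both stereocentres at the saturated ring carbons gives a 3.8-fold higher number from compound 1 to compound 4 (0.57 log units; beyond the scatter), the first size this set offers for a change of configuration alone. With every atom and bond kept, the gap can be put down to the arrangement at these two ring carbons and to nothing else in the structure, because of what separates the pair: the fact that compounds 1 and 4 differ only in the configuration as drawn. The mirror image still inhibits, as compound 4 gives 1050 nM, so configuration at these carbons shifts the number in this assay without removing the activity.

As far as these compounds go, both stereocentres invert together in this pair, and how the step divides between them stays open, as does which of the two carries more of it. From the compounds shown here alone, it is also open whether a step of this size would hold with another group, such as a methoxy group or a nitrile, in place of the trifluoromethyl group.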